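Pyrazole aniline series: methyl to methoxy at the aryl group

The compounds below may be only part of what the source reports. "The series", "measured", "known", "first", "only" and "open" are said of these compounds alone.

Measured so far:
compound 1, `Clc1ccc(NCc2cn(-c3ccccc3)nc2-c2ccc(Br)cc2)cc1`, 4150 nM
compound 2, `Cc1ccc(-c2nn(-c3ccccc3)cc2CNc2ccc(Cl)cc2)cc1`, 6020 nM

In a functional assay on MCF7 cells (Homo sapiens) for antiproliferative activity, read by MTT assay, with a stated time of 48 h (a lower number here means a stronger inhibitor, a higher number a weaker inhibitor), compound 2 sits with compound 1 inside the usual scatter; the two numbers do not separate. Going by the values given here, the only step on record is a 1.5-fold higher number from compound 1 to compound 2 (0.16 log units; within the scatter), which changed the same place now in question. Compound 3, `COc1ccc(-c2nn(-c3ccccc3)cc2CNc2ccc(Cl)cc2)cc1`, is not yet measured; it carries methoxy in place of methyl on an aromatic carbon. With a single comparable step that stayed within the scatter, no movement beyond the scatter is expected for compound 3 in this assay, and the estimated step is a 1.0-fold lower number from compound 2 to compound 3 (0.00 log units; within the scatter). Compound 3 is therefore expected near 6000 nM, with a range from 3000 nM to 12000 nM.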

Compound 3, half-maximal inhibitory concentration: 6250 nM
Beside the measured number, compound 3's estimate is 1.0-fold (0.02 log units) below it; the range from low to high includes it.
By their numbers in this assay, from the lowest: compounds 1, 2 and 3 (each within the scatter of the next).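

In this assay, the change from 4-methylphenyl to 4-methoxyphenyl gives a 1.0-fold higher number from compound 2 to compound 3 (0.02 log units; within the scatter) and the replacement of bromo by methoxy gives a 1.5-fold higher number from compound 1 to compound 3 (0.18 log units; within the scatter) within the same series. This position therefore holds bromo, methyl and methoxy without the numbers separating, even though methoxy adds an oxygen and a hydrogen-bond acceptor to methyl. No data here bear on why these groups read alike.

From the compounds shown here alone, whether an amine, a carboxylic acid or a longer alkoxy chain at this position would move the number beyond the scatter remains open. Going by these compounds, whether the other parts of the shared core respond more strongly also remains open.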